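Adding a carbamate to a weak phospholipase inhibitor

The source may hold more compounds than are shown below. What is called first, only, known or untested is meant among the compounds shown, and "the series" means these compounds.

The three measured compounds share a two-ring core with a phenyl ring carrying a small substituent. Compound 1 `CCOC(=O)c1ccc(-c2ccc(OCC)cc2)s1` gives 70000 nM in an assay on COS-7 cells for inhibition of patatin-like phospholipase domain-containing protein 2 (Mus musculus); on this read-out higher numbers stand for weaker inhibition and lower numbers for stronger inhibition. Compound 2 `CCOC(=O)c1cccc(-c2ccc(N(C)C)cc2)c1` gives 40000 nM in this assay, and compound 3 `CN(C)c1ccc(-c2cccc(N)c2)cc1` gives 100000 nM. Compound 3 thus has the highest number of the three; its gap to compound 1 lies within the scatter, while the step of a 2.5-fold higher number from compound 2 to compound 3 (0.40 log units; beyond the scatter) lies beyond it.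

Compound 4 `CCOC(=O)Nc1cccc(-c2ccc(N(C)C)cc2)c1` differs from compound 3 in one place: ethoxycarbonyl in place of hydrogen on a nitrogen on an aromatic ring. For the measured compounds named here, only one measured step bears on this change, the one a 2.5-fold higher number from compound 2 to compound 3 (0.40 log units; beyond the scatter), in which the same group left an aromatic carbon and the number rose modestly. Here the group returns, though on a nitrogen rather than a carbon, so a modest lowering of the number is the most that can be expected, and the step of a 2.0-fold lower number from compound 3 to compound 4 (0.30 log units; within the scatter) is an estimate with wide uncertainty. For compound 4 the expected value in this assay is 50000 nM, with a range from 20000 nM to 150000 nM.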

Compound 4, half-maximal inhibitory concentration: 3000 nM
Compound 4: middle estimate off by 17-fold (1.22 log units), on the high side, and the stated range ends above it.
By their numbers in this assay, from the lowest: compound 4; then compounds 2, 1 and 3 (each within the scatter of the next, the first and the last beyond it).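

The earlier step showed only a modest change when amino replaced ethoxycarbonyl on an aromatic carbon, whereas placing ethoxycarbonyl on that amino nitrogen has a far larger effect in this assay, giving a 33-fold lower number from compound 3 to compound 4 (1.52 log units; beyond the scatter). The nitrogen link also counts: putting (ethoxycarbonyl)amino in place of ethoxycarbonyl on the aromatic carbon gives a 13-fold lower number from compound 2 to compound 4 (1.12 log units; beyond the scatter), so the same group goes with a much lower number when it sits on the nitrogen than when it sits on the carbon. Nothing available here explains why this change has so large an effect.

As far as these compounds go, it remains open whether acetyl, methoxycarbonyl or a longer chain such as butoxycarbonyl on that nitrogen would give a similarly low number. The compounds shown also leave open whether a urea in place of the (ethoxycarbonyl)amino group would keep it.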